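The compounds below may be only part of what the source reports. "The series", "measured", "known", "first", "only" and "open" are said of these compounds alone.

Compound 3 `COc1ccccc1Cc1cc2c(N)nc(-c3nc(C)cs3)nc2s1` stands second highest of the three numbers obtained so far in a functional assay on CHO-K1 cells for antagonist activity at adenosine receptor A1 (Homo sapiens), read by a beta-galactosidase reporter and cAMP accumulation, with stated times of 15 min and 6 h (on this read-out higher numbers stand for weaker inhibition and lower numbers for stronger inhibition), where compound 3 gives 186 nM. Compound 1 `COc1ccccc1Cc1cc2c(N)nc(-c3ccc(C)o3)nc2s1` lies nearest, and in this assay compound 1 gives 122 nM; the step of a 1.5-fold higher number from compound 1 to compound 3 (0.18 log units; within the scatter) is within the scatter, so the swap of the five-membered ring carries no signal here. Among the measured compounds shown here, compound 2 `Cc1csc(-c2nc(N)c3cc(Cc4ccccc4)sc3n2)n1` lies furthest, and in this assay compound 2 gives 1490 nM; the step of an 8.0-fold lower number from compound 2 to compound 3 (0.90 log units; beyond the scatter) is beyond the scatter and is the only measured step that bears on the present change.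

Compound 4 `Cc1csc(-c2nc(N)c3cc(Cc4ccccc4F)sc3n2)n1` has not yet been measured. Relative to compound 3 the change is fluoro in place of methoxy on an aromatic carbon. For the measured compounds named here, no measured step exchanges methoxy for fluoro directly. What is known is that the same position bare of any substituent, as in compound 2, carries a markedly higher number than the methoxy-bearing compound 3. Fluoro counts one heavy atom and no hydrogen-bond acceptor where methoxy counted two and one, so a number between those of compound 3 and compound 2 is expected, upward and probably beyond the scatter, but short of the full step seen on removing methoxy.

For compound 4 in this assay the estimate is 600 nM, with a range from 200 nM to 1800 nM. This estimate for compound 4 corresponds to an expected step of a 3.2-fold higher number from compound 3 to compound 4 (0.51 log units; beyond the scatter).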

Compound 4, inhibition constant: 28.6 nM
Compound 4: middle estimate off by 21-fold (1.32 log units), on the high side, and the stated range ends above it.
By their numbers in this assay, from the lowest: compound 4; then compounds 1 and 3 (each within the scatter of the next); then compound 2.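

In this assay, the substituent ortho to a large group on the six-membered aromatic ring of carbon only clearly matters, and the methoxy of compound 3 does not mark the best result at this place among the compounds shown. The change from 2-methoxyphenyl to 2-fluorophenyl gives a further gain (a 6.5-fold lower number from compound 3 to compound 4 (0.81 log units; beyond the scatter)), and against the unsubstituted ring the gain is larger still (a 52-fold lower number from compound 2 to compound 4 (1.72 log units; beyond the scatter)), so among compounds 2, 3 and 4 the numbers run from hydrogen through methoxy to fluoro, and neither the greater heavy-atom count of methoxy nor its hydrogen-bond acceptor is needed for a low number. No measurement shown here explains why fluoro gives the lower number at this place.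

Among the compounds shown here, with only three groups compared at this place, all on the 4-methyl-1,3-thiazol-2-yl series, it remains open whether fluoro gives a similar gain with the 5-methylfuran-2-yl group of compound 1. On these data alone, it is also open how chloro, trifluoromethyl, hydroxyl or an amine would compare at this place, and whether fluoro on another carbon of the same ring would do as well.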